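Swapping the five-membered ring on an alpha-1D receptor agonist

A few compounds are considered here, and "the series" means these few. Any claim that something is new, unique, unknown or untested is made for them only; others in the source may bear on it.

Compound 1 `Cn1cccc1-c1ccccc1NCC1=NCCN1`: 32%
Compound 2 `CCCn1nccc1-c1ccccc1NCC1=NCCN1`: 0%
Compound 3 `Cn1ccnc1-c1ccccc1NCC1=NCCN1`: 92%

In a functional assay with Alpha-1D adrenergic receptor (Homo sapiens) as the target, read by calcium flux (on this read-out lower numbers stand for smaller maximal responses and higher numbers for larger maximal responses), compound 3 gives 92%, the highest of the three numbers; compound 1 comes nearest and compound 2 lies furthest away, both beyond the scatter. Going by the values given here, the one single-point step available, a number 60 percentage points higher from compound 1 to compound 3 (beyond the scatter), shows that exchanging the five-membered ring on this core can move the maximal response a long way.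

Compound 4 `Cn1nccc1-c1ccccc1NCC1=NCCN1` has not yet been measured. It differs from compound 3 by 1-methyl-1H-pyrazol-5-yl in place of 1-methyl-1H-imidazol-2-yl on an aromatic carbon. Among the compounds with values here, no measured step covers exactly this exchange. Compound 2, which carries a 1-propyl-1H-pyrazol-5-yl group at the same place, gives 0%, while compound 1, with 1-methyl-1H-pyrrol-2-yl, gives 32%; both are far below compound 3. A large downward step is therefore expected, a number 72 percentage points lower from compound 3 to compound 4 (beyond the scatter). Compound 4 is estimated to reach 20% in this assay, within a range from 0% to 55%.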

Compound 4, largest response reached (reported as maximal response), in percent of the reference or control that the assay uses: 0%
The estimate for compound 4 lay 20 percentage points above the measured number; measured number inside the range.
By their numbers in this assay, from the lowest: compounds 2 and 4 (each within the scatter of the next); then compound 1; then compound 3.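

In this assay, a number 92 percentage points lower from compound 3 to compound 4 (beyond the scatter), although the two rings have the same atoms and the same counts of hydrogen-bond donors and acceptors, so how those atoms are joined matters greatly at this aromatic carbon. The 1-methyl-1H-pyrazol-5-yl group also compares poorly with the 1-methyl-1H-pyrrol-2-yl group: a number 32 percentage points lower from compound 1 to compound 4 (beyond the scatter). Shortening the chain on the pyrazole nitrogen from propyl to methyl gives no change at the digits printed from compound 2 to compound 4 (within the scatter), so among these two compounds the length of that chain does not separate the results.

Nothing in the data shown explains why joining the same atoms differently has such a large effect. Going by these compounds, it also remains open what a propyl chain on the imidazole nitrogen of compound 3, or a thiazole ring at this same place, would do to the maximal response.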